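Swapping the Ring on Compound 2: What to Expect

The source may hold more compounds than are shown below. What is called first, only, known or untested is meant among the compounds shown, and "the series" means these compounds.

Compound 1 `Oc1cccc(NC(=S)NCc2ccccc2)c1` gives 200000 nM in a functional assay on RAW264.7 cells (Mus musculus) for inhibition, read by Griess assay, with a stated time of 24 h; on this read-out lower numbers stand for stronger inhibition and higher numbers for weaker inhibition. Compound 2 `S=C(Nc1ccccc1)N1CCN(c2ncccn2)CC1` is reported only as a limit of this assay, >= 200000 nM. Compound 3 `S=C(NCc1ccccc1)N1CCN(c2ncccn2)CC1` likewise reaches only a limit, >= 200000 nM. The change between them, benzyl in place of phenyl on an amide-type nitrogen, therefore yields a step that the two limits leave unreadable from compound 2 to compound 3. Compound 2 thus stands at the edge of what this assay can report, a position shared by two of the three values shown (the limit of >= 200000 nM in this assay, at which 2 of the 3 values shown sit). Compound 4 `S=C(Nc1ccccc1)N1CCN(c2ccccc2Cl)CC1` differs from compound 2 by 2-chlorophenyl in place of pyrimidin-2-yl on an amine nitrogen in a ring. Among the measured compounds shown here, no measured step covers such a ring exchange, so the only guide is where compound 2 stands. Compound 4 is therefore expected to shift little, with a number no higher from compound 2 to compound 4 (the limit leaves the size open), and its estimated value is 200000 nM, ranging from 60000 nM to 400000 nM, most likely again as a limit.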

Compound 4, half-maximal inhibitory concentration: >= 200000 nM
Compound 4 ended at the assay's limit; the forecaster's own chance of this, stated with the estimate: 70%; the middle value sits exactly at the limit.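

Compound 2 and compound 4 are both reported only as limits in this assay, so no step can be read between them: the limit of >= 200000 nM in this assay, at which 3 of the 4 values shown sit.

On these data alone, whether 2-chlorophenyl in place of pyrimidin-2-yl changes inhibition at all remains open.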